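The source may hold more compounds than are shown below. What is called first, only, known or untested is meant among the compounds shown, and "the series" means these compounds.

Notes on the series. In a functional assay on CHO cells for agonist activity at Free fatty acid receptor 1 (Homo sapiens), read by FLIPR and calcium flux, tested at 100 nM (on this read-out lower numbers stand for a weaker effect and higher numbers for a stronger effect at the one concentration tested), compound 1 `Cc1nc(-c2cccs2)sc1COc1ccc2c(c1)OCC2CC(=O)O` gives 35.2%, the highest of the three numbers measured. Compound 2 `Cc1nc(-c2ccc(Cl)s2)sc1COc1ccc2c(c1)OCC2CC(=O)O` gives 8.34% in this assay, and compound 3 `Cc1ccccc1-c1nc(C)c(COc2ccc3c(c2)OCC3CC(=O)O)s1` gives 10.7%, so that a number 26.9 percentage points lower from compound 1 to compound 2 (beyond the scatter) and a number 24.5 percentage points lower from compound 1 to compound 3 (beyond the scatter), both beyond the scatter; between compounds 2 and 3 the step is a number 2.4 percentage points higher from compound 2 to compound 3 (within the scatter).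

Compound 4 `Cc1nc(-c2cccc(C(F)(F)F)c2)sc1COc1ccc2c(c1)OCC2CC(=O)O` is not yet measured. It differs from compound 1 by 3-(trifluoromethyl)phenyl in place of thiophen-2-yl on an aromatic carbon. Among the compounds with values here, of the measured steps, the closest in kind is the one from compound 1 to compound 3, where thiophen-2-yl was likewise replaced by a substituted phenyl; that step was a number 24.5 percentage points lower from compound 1 to compound 3 (beyond the scatter). A step of similar size and direction is therefore expected, namely a number 23.2 percentage points lower from compound 1 to compound 4 (beyond the scatter). Compound 4 is estimated at 12%, within 2% to 30%.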

Compound 4, a percentage reported as activity, at one concentration (the size of the read-out at that concentration, not a potency): 35.7%
Estimate against measurement, compound 4: 23.7 percentage points below; measured number outside the range, above it.
By their numbers in this assay, from the lowest: compounds 2 and 3 (each within the scatter of the next); then compounds 1 and 4 (each within the scatter of the next).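

Replacing thiophen-2-yl with a six-membered aromatic ring is not in itself a loss at this position: with 3-(trifluoromethyl)phenyl, the result is a number 0.5 percentage points higher from compound 1 to compound 4 (within the scatter). The substituted phenyl groups do not behave alike in this assay, with a number 25 percentage points higher from compound 3 to compound 4 (beyond the scatter), and the thiophene comparison gives a number 27.4 percentage points higher from compound 2 to compound 4 (beyond the scatter). Nothing available explains these differences.

From the compounds shown here alone, whether a plain phenyl, or a phenyl bearing a nitrile or an amine, would read like compound 4 remains open. A single-concentration read-out also leaves the relative potency of compound 1 and compound 4 open.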